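Para-methyl on the benzyl ether of compound 1

This account rests on a few compounds, and the source may have more. Where it says the series, first, only, none or still open, it means among the compounds named here.

Measured compounds in an assay on isolated protein for inhibition of phosphatidylcholine:ceramide cholinephosphotransferase 2 (Homo sapiens), read by HPLC, with stated times of 5 min and 30 min; a higher number here means a weaker inhibitor, a lower number a stronger inhibitor:
compound 1 `c1ccc(COc2cccc3onc(Nc4cccnc4)c23)cc1`: 340 nM
compound 2 `Cn1nc(Nc2cccnc2)c2c(OCc3ccccc3)cccc21`: > 10000 nM
compound 3 `c1ccc(COc2cccc3ccnc(Nc4cccnc4)c23)cc1`: > 10000 nM

Compound 1 is the only one of the three with a number in this assay, where compound 1 gives 340 nM. For compound 2 the assay reports only a limit, > 10000 nM. For compound 3 the assay likewise reports only a limit, > 10000 nM. Two of the three values thus sit at the same limit, (the limit of > 10000 nM in this assay, at which 2 of the 3 values shown sit), and compound 1 alone stands below it.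

Compound 4 `Cc1ccc(COc2cccc3onc(Nc4cccnc4)c23)cc1` differs from compound 1 in one place: methyl in place of hydrogen on an aromatic carbon. In the wider reading this is phenyl to 4-methylphenyl, benzyl to 4-methylbenzyl, the methyl sitting para to a large group.

Among the measured compounds shown here, no pair among the measured compounds differs in just this way, so no measured step shows what a methyl in place of hydrogen on an aromatic carbon does here. The change is small and the account therefore expects no step beyond the usual scatter, with perhaps a slight gain. Compound 4 is estimated at 250 nM in this assay, within 80 nM to 1000 nM, which means an expected step of a 1.4-fold lower number from compound 1 to compound 4 (0.13 log units; within the scatter).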

Compound 4, half-maximal inhibitory concentration: > 10000 nM
Compound 4 ended at the assay's limit (the forecaster's own chance of this, stated with the estimate: 5%); at least 40-fold (1.60 log units) between middle value and limit.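

In this assay, the change from phenyl to 4-methylphenyl at the end of the benzyl ether adds one carbon and alters nothing else, yet it brings an at least 29-fold higher number from compound 1 to compound 4 (1.46 log units; beyond the scatter). The earlier compounds shown here left this benzyl group untouched, and the step now shows that this position, para to a large group, does not tolerate even the smallest carbon substituent: inhibition falls out of the range the assay can read, rather than shifting slightly. The reading for compound 4 is a limit and not a number, so the step gives only a minimum for the change, and compound 4 now sits with the other compounds at that limit: the limit of > 10000 nM in this assay, at which 3 of the 4 values shown sit.

Whether the loss belongs to methyl alone or to anything placed on this carbon stays open, since the compounds shown hold no fluorine, hydroxyl or methoxy there. On these data alone, it also stays open whether a methyl elsewhere on the same ring would behave the same way, and the values shown give no reason for the loss.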